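Moving one fluorine: from compound 2 to compound 3

The compounds below may be only part of what the source reports. "The series", "measured", "known", "first", "only" and "open" are said of these compounds alone.

Values so far in a functional assay on MDA-MB-231 cells (Homo sapiens) for antiproliferative activity, read by MTT assay, with a stated time of 72 h; on this read-out lower numbers stand for stronger inhibition and higher numbers for weaker inhibition
- compound 1 `CC1=CC[C@H]2[C@H](CC[C@]2(C)O)C(C)(C)[C@@H]1CC[C@H]1[C@]2(C)CC[C@H](OC(=O)c3ccc(F)cc3)C(C)(C)O[C@H]2CC[C@@]1(C)O` gives 11300 nM
- compound 2 `CC1=CC[C@H]2[C@H](CC[C@]2(C)O)C(C)(C)[C@@H]1CC[C@H]1[C@]2(C)CC[C@H](OC(=O)c3ccc(C(F)(F)F)cc3F)C(C)(C)O[C@H]2CC[C@@]1(C)O` gives 36300 nM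

Compound 2 stands at 36300 nM as the higher of the two numbers in the series. Compound 3 `CC1=CC[C@H]2[C@H](CC[C@]2(C)O)C(C)(C)[C@@H]1CC[C@H]1[C@]2(C)CC[C@H](OC(=O)c3ccc(C(F)(F)F)c(F)c3)C(C)(C)O[C@H]2CC[C@@]1(C)O` is still unmeasured and has the same atoms as compound 2, joined differently. It carries 3-fluoro-4-(trifluoromethyl)phenyl in place of 2-fluoro-4-(trifluoromethyl)phenyl on a carbonyl carbon.

Among the compounds with values here, only one measured step bears on this change. That step is a 3.2-fold higher number from compound 1 to compound 2 (0.51 log units; beyond the scatter) and it is modest, lying beyond the scatter. It replaced 4-fluorophenyl on the same carbonyl carbon, so it gives a scale for changes at this place. Within the data shown here, no measured pair shows the effect of moving the fluorine alone. A change of joining only is therefore expected to be smaller than that step, with a weak lean toward lower numbers, as compound 1 at 11300 nM is the only other reference. The expected step, a 1.4-fold lower number from compound 2 to compound 3 (0.14 log units; within the scatter), is estimated to stay within the scatter. For compound 3 the estimate is 26000 nM with 11000 nM to 60000 nM as the expected range.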

Compound 3, half-maximal inhibitory concentration: 22200 nM
Compound 3: the middle estimate sits 1.2-fold (0.07 log units) above what was measured; measured number inside the range.
By their numbers in this assay, from the lowest: compounds 1, 3 and 2 (each within the scatter of the next, the first and the last beyond it).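

In this assay, 3-fluoro-4-(trifluoromethyl)phenyl in place of 2-fluoro-4-(trifluoromethyl)phenyl on a carbonyl carbon gives a 1.6-fold lower number from compound 2 to compound 3 (0.21 log units; within the scatter), the first read on the placing of the fluorine alone, and that placing is not resolved from the scatter. Against 4-fluorophenyl, the same group gives a 2.0-fold higher number from compound 1 to compound 3 (0.29 log units; within the scatter), whereas the earlier step was a 3.2-fold higher number from compound 1 to compound 2 (0.51 log units; beyond the scatter), so compound 3 cannot be separated from either of the other two, although those two remain apart. Nothing available accounts for these differences among the three aryl groups.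

Still open, from the compounds shown here alone, is how the step from compound 1 to compound 2 divides between the trifluoromethyl group and the ring fluorine, a question that a phenyl ring bearing trifluoromethyl alone would address. Also open, going by these compounds, is whether a nitrile or an amine on this ring, or a longer chain in place of the ring, would move the number in this assay beyond the scatter of these three compounds.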